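Only limits so far: from compound 3 to compound 4

A few compounds are considered here, and "the series" means these few. Any claim that something is new, unique, unknown or untested is made for them only; others in the source may bear on it.

Three esters have been read in a functional assay on the whole organism (strain Kunming) with Mus musculus as the target, with a stated time of 0.5 h (on this read-out lower numbers stand for an effect already at smaller amounts and higher numbers for an effect only at larger amounts of compound), and none has yet given a number. Compound 1 `COc1cc(OC)c(OC)cc1/C=C/COC(=O)/C=C/c1c(OC)ccc(OC)c1OC` shows > 674 umol/kg as a limit of the assay. Compound 2 `COc1cc(OC)c(OC)cc1/C=C/COC(=O)/C=C/c1cc(OC)c(OC)c(OC)c1OC` shows > 421 umol/kg as a limit too. Compound 3 `COc1cc(OC)c(OC)cc1/C=C/COC(=O)/C=C/c1ccccc1C(F)(F)F` shows > 710 umol/kg as a limit as well. Compound 3 therefore has no measured dose, and the three limits give no ranking within the series.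

The next ester is compound 4 `COc1cccc(/C=C/C(=O)OC/C=C/c2cc(OC)c(OC)cc2OC)c1`. The change 3-methoxyphenyl in place of 2-(trifluoromethyl)phenyl on a double-bonded chain carbon bound to a double-bonded chain carbon places 3-methoxyphenyl in place of 2-(trifluoromethyl)phenyl on a double-bonded chain carbon bound to a double-bonded chain carbon. Going by the values given here, no measured pair differs in one place only, so no observed step can serve as a guide for this exchange.

In this assay the expectation is no shift beyond the usual scatter, and a further limit is the likeliest report. This rests on compound 1, compound 2 and compound 3 all ending as limits, with no number among them. The estimated step of an at least 1.2-fold lower number from compound 3 to compound 4 (0.11 log units; that floor lies within the scatter) is expected to stay small and has no firm direction. For compound 4 a dose of 550 umol/kg is estimated, with an expected range from 180 umol/kg to 1000 umol/kg if a number is obtained at all.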

Compound 4, dose for half-maximal effect: 647 umol/kg
The estimate for compound 4 lay 1.2-fold (0.07 log units) below the measured number; the measured number falls inside the stated range.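

In this assay compound 4 is the only ester shown so far with a number, 647 umol/kg, so with 3-methoxyphenyl on a double-bonded chain carbon bound to a double-bonded chain carbon the series reaches a readable dose. The exchange of 2-(trifluoromethyl)phenyl for 3-methoxyphenyl at this place reads as an at least 1.0-fold lower number from compound 3 to compound 4 (0.04 log units; that floor lies within the scatter), and since the starting point of that step is not a number, neither its true size nor its direction is fixed beyond that floor. The starting value is a limit and not a number: the limit of > 710 umol/kg in this assay, at which 1 of the 4 values shown sits.

As far as these compounds go, whether the number for compound 4 belongs to the 3-methoxyphenyl group in particular stays open, since a single dose cannot separate the methoxy group from the loss of trifluoromethyl. Also open, from the compounds shown here alone, is how this assay would respond to an amine or a carboxylic acid on the aromatic ring at this place, or to a longer chain between that ring and the ester carbonyl.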